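Dibromophenyl amide in the cytotoxicity series

The source may hold more compounds than are shown below. What is called first, only, known or untested is meant among the compounds shown, and "the series" means these compounds.

Three analogues on one shared core have been read in a functional assay on C8166 cells (Homo sapiens) for cytotoxicity, read by MTT assay; on this read-out higher numbers stand for lower toxicity in this test and lower numbers for higher toxicity in this test. Compound 1 `Cc1cc(S(N)(=O)=O)ccc1NC(=O)COc1ccc(Cl)cc1NC(=O)c1cccc(F)c1` gives 243000 nM. Compound 2 `COc1ccc(C(=O)Nc2cc(Cl)ccc2OCC(=O)Nc2ccc(S(N)(=O)=O)cc2C)cc1` gives 69500 nM. Compound 3 `Cc1cc(S(N)(=O)=O)ccc1NC(=O)COc1ccc(Cl)cc1NC(=O)c1cc(Cl)cc(Br)c1` gives 114000 nM. Compound 2 stands lowest of the three numbers: the step of a 3.5-fold lower number from compound 1 to compound 2 (0.54 log units; beyond the scatter) lies beyond the scatter, as does a 2.1-fold lower number from compound 1 to compound 3 (0.33 log units; beyond the scatter), whereas a 1.6-fold higher number from compound 2 to compound 3 (0.21 log units; within the scatter) does not, so compound 2 and compound 3 cannot be separated in this assay.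

Compound 4 `Cc1cc(S(N)(=O)=O)ccc1NC(=O)COc1ccc(Cl)cc1NC(=O)c1cc(Br)cc(Br)c1` has not yet been measured. Its change from compound 2 is 3,5-dibromophenyl in place of 4-methoxyphenyl on a carbonyl carbon. Within the data shown here, the one measured step that bears on this is a 1.6-fold higher number from compound 2 to compound 3 (0.21 log units; within the scatter), where 3-bromo-5-chlorophenyl took the place of the same 4-methoxyphenyl on the carbonyl carbon; 3,5-dibromophenyl is the nearest relative of that group among the three. A comparably small movement is therefore expected, most likely upward toward compound 3, without confidence that it clears the scatter. Compound 4 is expected to give 110000 nM in this assay, within a range of 50000 nM to 250000 nM. The implied step a 1.6-fold higher number from compound 2 to compound 4 (0.20 log units; within the scatter) is expected to stay modest.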

Compound 4, half-maximal cytotoxic concentration: 89700 nM
Estimate against measurement, compound 4: 1.2-fold (0.09 log units) above; measured number inside the range.
By their numbers in this assay, from the lowest: compounds 2, 4 and 3 (each within the scatter of the next); then compound 1.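

On the carbonyl carbon, 3,5-dibromophenyl cannot be separated from 4-methoxyphenyl in this assay: the change reads a 1.3-fold higher number from compound 2 to compound 4 (0.11 log units; within the scatter), even though a ring with one hydrogen-bond acceptor gives way to a ring with none. Bromo in place of chloro on an aromatic carbon is likewise unresolved, with a 1.3-fold lower number from compound 3 to compound 4 (0.10 log units; within the scatter) as the reading, so this halogen swap gives no measurable separation here. The 3-fluorophenyl of compound 1 now stands apart from three other aryl groups, since a 2.7-fold lower number from compound 1 to compound 4 (0.43 log units; beyond the scatter) is a further step beyond the scatter, though a modest one.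

No measurement at hand explains any of these readings. Open, going by these compounds, is whether a group of another kind on the carbonyl carbon, such as a pyridine ring, a carboxylic acid-bearing phenyl ring or a plain alkyl chain, would separate from compound 2, compound 3 and compound 4.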